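The source may report more compounds than this note shows. Statements on the series, on what has been measured and on what is new or still open speak of the compounds shown alone.

Measured compounds in the series:

compound 1 `CCCCc1ccc(-c2cc(N3CCC(CCNS(N)(=O)=O)CC3)ncn2)cc1`: 11300 nM
compound 2 `NS(=O)(=O)NCCC1CCN(c2cc(-c3ccc(Cl)cc3)ncn2)CC1`: 19700 nM

Both numbers come from a functional assay on MCF7 cells (Homo sapiens) for antiproliferative activity, read by sulforhodamine B assay, with a stated time of 48 h; on this read-out higher numbers stand for weaker inhibition of growth and lower numbers for stronger inhibition of growth. For the measured compounds named here, compound 2 holds the highest of the two numbers; its nearest neighbour is compound 1, and the one measured step, a 1.7-fold higher number from compound 1 to compound 2 (0.24 log units; within the scatter), stays within the scatter, so the two compounds cannot be ordered on these data.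

Compound 3 `CCOC(=O)c1ccc(-c2cc(N3CCC(CCNS(N)(=O)=O)CC3)ncn2)cc1` is the next compound to be read in this assay. Against compound 2 the change is ethoxycarbonyl in place of chloro on an aromatic carbon, on an aromatic carbon of a six-membered aromatic ring of carbon only, para to a large group.

Going by the values given here, the only step that bears on this position is the one from compound 1 to compound 2, and that step did not leave the scatter. Nothing measured speaks to an ethoxycarbonyl at this place, so no step beyond the scatter is expected in this assay in either direction, with the estimate kept close to compound 2.

Compound 3 is therefore expected at about 15000 nM, a step of a 1.3-fold lower number from compound 2 to compound 3 (0.12 log units; within the scatter), with a range of 5000 nM to 50000 nM.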

Compound 3, concentration for 50% growth inhibition: 6200 nM
Beside the measured number, compound 3's estimate is 2.4-fold (0.38 log units) above it; the range from low to high includes it.
By their numbers in this assay, from the lowest: compounds 3, 1 and 2 (each within the scatter of the next, the first and the last beyond it).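

In this assay, this position, on an aromatic carbon para to a large group, now shows a response: ethoxycarbonyl in place of chloro gives a 3.2-fold lower number from compound 2 to compound 3 (0.50 log units; beyond the scatter), a modest step and the first in the series to leave the scatter. Against butyl at the same place, the ethoxycarbonyl group gives a 1.8-fold lower number from compound 1 to compound 3 (0.26 log units; within the scatter), so compound 3 separates from compound 2 only and cannot be ranked ahead of compound 1, while the position is seen to accept a group of 5 heavy atoms with 2 hydrogen-bond acceptors without a rise in the number against either earlier compound. No measurement among these data accounts for the step.

Going by these compounds, whether the lower number belongs to the ester as such stays open, since a carboxylic acid, a primary amide or a methyl ester at this place would be needed to tell that apart from the mere presence of a larger group. On these data alone, all three compounds also share the same core and side chain, so the effect of a longer chain between the saturated ring and the terminal group remains unknown, as does whether the step at this position would hold with such a change.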